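This account rests on a few compounds, and the source may have more. Where it says the series, first, only, none or still open, it means among the compounds named here.

In an ADME assay for permeability, using PAMPA, with a stated time of 4 h, at pH 5.5; a higher number here means that the compound crosses the layer faster, a lower number that the compound crosses the layer more slowly:
- Compound 1 `NC/C=C\CN(C[C@H]1Cc2ncccc2CN1)[C@H]1CCCc2cccnc21`: 28 nm/s
- Compound 2 `CCN(CC)CCCCN(C[C@H]1Cc2ncccc2CN1)[C@H]1CCCc2cccnc21`: 3 nm/s

Compound 2, at 3 nm/s, holds the lower of the two numbers, clearly under compound 1. The next compound, compound 3 `c1cnc2c(c1)CN[C@@H](CN(CCCCNC1COC1)[C@H]1CCCc3cccnc31)C2`, has (oxetan-3-yl)amino in place of diethylamino on a saturated chain carbon, four bonds along the chain from an amine nitrogen.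

Among the compounds with values here, only one measured step bears on this change: a 9.3-fold lower number from compound 1 to compound 2 (0.97 log units; beyond the scatter). That step brought in the diethylamino group that now leaves, so a partial move back upward in this assay seems likely. Within the data shown here, the group entering here differs from the one in compound 1, however, and a single step is a weak guide. The expected change, smaller than that earlier step, is a 3.0-fold higher number from compound 2 to compound 3 (0.48 log units; beyond the scatter). For compound 3 the estimated value is 9 nm/s, with an expected range of 3 nm/s to 30 nm/s.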

Compound 3, apparent permeability: 7 nm/s
Compound 3: the middle estimate sits 1.3-fold (0.11 log units) above what was measured, within the range that was stated.
By their numbers in this assay, from the lowest: compound 2; then compound 3; then compound 1.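

In this assay, putting (oxetan-3-yl)amino in place of diethylamino on this saturated chain carbon gives a 2.3-fold higher number from compound 2 to compound 3 (0.37 log units; beyond the scatter), a step beyond the scatter even though the two groups hold the same count of heavy atoms. The number does not return to the top of the series, and a clear gap remains: a 4.0-fold lower number from compound 1 to compound 3 (0.60 log units; beyond the scatter). No measured evidence here gives a reason for either step.

The ring, the oxygen and the amine hydrogen all change together in this one swap, so the compounds shown do not tell their contributions apart. Going by these compounds, it also remains open whether a cyclobutylamino group or a plain amino group at this place would give a number nearer to that of compound 2 or to that of compound 1.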